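Turning one ring carbon over in compound 3

A few compounds are considered here, and "the series" means these few. Any claim that something is new, unique, unknown or untested is made for them only; others in the source may bear on it.

Of the compounds shown here, three built on a shared core have been tested in a functional assay on CCRF-CEM cells for antagonist activity at C-X-C chemokine receptor type 4 (Homo sapiens), read by calcium flux, with stated times of 25 min and 90 s; on this read-out lower numbers stand for stronger inhibition and higher numbers for weaker inhibition. Compound 1 `CN(C[C@H]1Cc2c(cccc2N2CCN(C3COC3)CC2)CN1)[C@H]1CCCc2cccnc21` gives 381 nM, compound 2 `CN(C[C@H]1Cc2c(cccc2N2CCNC(C)(C)C2)CN1)[C@H]1CCCc2cccnc21` gives 33.9 nM, and compound 3 `CN(C[C@H]1Cc2c(cccc2N2CCN3CCC[C@H]3C2)CN1)[C@H]1CCCc2cccnc21` gives 2.92 nM. Compound 3 stands lowest of the three: one measured step is a 12-fold lower number from compound 2 to compound 3 (1.06 log units; beyond the scatter), and another is a 130-fold lower number from compound 1 to compound 3 (2.12 log units; beyond the scatter). The remaining measured step, an 11-fold lower number from compound 1 to compound 2 (1.05 log units; beyond the scatter), is also large.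

Compound 4 `CN(C[C@H]1Cc2c(cccc2N2CCN3CCC[C@@H]3C2)CN1)[C@H]1CCCc2cccnc21` is the next candidate. Its difference from compound 3 is the two compounds have the same atoms and bonds and differ only in configuration as drawn: 1 of 3 stereo elements differ; a stereocentre at a saturated ring carbon is drawn S in compound 3 and R in compound 4. None of the three measured steps bears on this kind of change: each of them swapped one group for another, whereas here nothing leaves and nothing enters. There is thus no measured guide to the direction, and a change in configuration at a ring carbon can leave the number alone or move it either way, often by a large step. The estimate for compound 4 is therefore a somewhat weaker number, expected to move by a 4.1-fold higher number from compound 3 to compound 4 (0.61 log units; beyond the scatter) to about 12 nM, with a wide range from 2.5 nM to 60 nM.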

Compound 4, half-maximal inhibitory concentration: 3.59 nM
Compound 4: middle estimate off by 3.3-fold (0.52 log units), on the high side, within the range that was stated.
By their numbers in this assay, from the lowest: compounds 3 and 4 (each within the scatter of the next); then compound 2; then compound 1.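

In this assay the step is a 1.2-fold higher number from compound 3 to compound 4 (0.09 log units; within the scatter), so drawing this saturated ring carbon as S or as R leaves the two compounds indistinguishable on this read-out. The advantage over the other groups holds for the R form too, with a 9.4-fold lower number from compound 2 to compound 4 (0.98 log units; beyond the scatter) and a 110-fold lower number from compound 1 to compound 4 (2.03 log units; beyond the scatter), so the lower numbers go with the group holding the five-membered ring in either configuration, not with just one of them. This comparison speaks to configuration alone because only one thing separates the pair: the fact that compounds 3 and 4 differ only in the configuration as drawn

The compounds shown leave open whether inverting either of the other two stereo elements would be equally without consequence. They also leave open how a morpholin-4-yl group would compare with these groups on the same aromatic carbon.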